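Compound 3 to compound 4: 3,4-dichlorophenyl in place of carboxy

The source may hold more compounds than are shown below. What is called first, only, known or untested is meant among the compounds shown, and "the series" means these compounds.

In a functional assay on SEM cells (Homo sapiens) for cytotoxicity, with a stated time of 72 h (a higher number here means that more compound is needed for the effect, a lower number that less compound is needed), compound 1 (`C=C[C@@](C)(/C=C/c1ccc(O)c(/C=C/C(=O)c2ccccc2)c1)CCC=C(C)C`) gives 8000 nM. Compound 2 (`C=C[C@@](C)(/C=C/c1ccc(O)c(/C=C/C#N)c1)CCC=C(C)C`) gives > 36600 nM, which is a limit and not a number. Compound 3 (`C=C[C@@](C)(/C=C/c1ccc(O)c(/C=C/C(=O)O)c1)CCC=C(C)C`) gives > 36600 nM, also a limit and not a number. Its standing is therefore (the limit of > 36600 nM in this assay, at which 2 of the 3 values shown sit).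

The next change leads to compound 4 (`C=C[C@@](C)(/C=C/c1ccc(O)c(/C=C/c2ccc(Cl)c(Cl)c2)c1)CCC=C(C)C`): 3,4-dichlorophenyl in place of carboxy on a double-bonded chain carbon bound to a double-bonded chain carbon. In words, 3,4-dichlorophenyl comes in place of carboxy on a double-bonded chain carbon bound to a double-bonded chain carbon.

Among the measured compounds shown here, two measured steps bear on this change: an at least 4.5-fold higher number from compound 1 to compound 2 (0.66 log units; beyond the scatter) and an at least 4.5-fold higher number from compound 1 to compound 3 (0.66 log units; beyond the scatter). Both lose the phenyl of compound 1, and both are beyond the scatter, though their full size is hidden by the limit. By contrast, a step that the two limits leave unreadable from compound 2 to compound 3 offers no guidance. Compound 4 regains an aromatic ring at the chain end, but without the carbonyl of compound 1, so the comparison is imperfect. The expectation is therefore a lower number in this assay, close to compound 1 with 8000 nM. A further limit for compound 4 remains possible. The expected change is an at least 3.6-fold lower number from compound 3 to compound 4 (0.56 log units; beyond the scatter). The estimate for compound 4 is 10000 nM, with an expected range from 3000 nM to 30000 nM.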

Compound 4, half-maximal effective concentration: > 7500 nM
Compound 4 was reported as a limit (the forecaster's own chance of this, stated with the estimate: 25%); the middle value is on the limit's open side.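

In this assay compound 4 gives > 7500 nM, which is a limit and not a number. Among the compounds shown here, no step from compound 1, compound 2 or compound 3 to compound 4 can be read. The compounds shown leave open whether 3,4-dichlorophenyl in place of benzoyl, cyano or carboxy changes the number at all, and by how much.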